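Replacing 1H-benzimidazol-2-yl with 4-phenyl-1H-imidazol-2-yl

The source may report more compounds than this note shows. Statements on the series, on what has been measured and on what is new or still open speak of the compounds shown alone.

In a functional assay on HCT-116 cells (Homo sapiens) for antiproliferative activity, read by luminescence, with a stated time of 72 h (a higher number here means a weaker inhibitor, a lower number a stronger inhibitor), compound 1 `CN1CC=C(c2c(O)cc(O)c3c(=O)cc(-c4ccc(Sc5nc6ccccc6[nH]5)cc4)oc23)CC1` gives 293 nM and compound 2 `CN1CC=C(c2c(O)cc(O)c3c(=O)cc(-c4ccc(Sc5nc6ccccc6[nH]5)cc4Cl)oc23)CC1` gives 170 nM so these two sit within the scatter of each other. Compound 3 `CN1CC=C(c2c(O)cc(O)c3c(=O)cc(-c4ccc(Sc5nc(-c6ccccc6)c[nH]5)cc4)oc23)CC1` carries 4-phenyl-1H-imidazol-2-yl in place of 1H-benzimidazol-2-yl on a sulfur. Among the measured compounds shown here, the only measured step (a 1.7-fold lower number from compound 1 to compound 2 (0.24 log units; within the scatter)) puts chloro in place of hydrogen, a different change that offers no direction for this one. In this assay no step beyond the scatter is therefore expected (a 1.0-fold higher number from compound 1 to compound 3 (0.01 log units; within the scatter)). For compound 3 the estimate is 300 nM with an expected range from 100 nM to 900 nM in this measurement.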

Compound 3, half-maximal inhibitory concentration: 173 nM
Estimate against measurement, compound 3: 1.7-fold (0.24 log units) above; the measured number falls inside the stated range.
By their numbers in this assay, from the lowest: compounds 2, 3 and 1 (each within the scatter of the next).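

In this assay, exchanging the group on the sulfur gives a 1.7-fold lower number from compound 1 to compound 3 (0.23 log units; within the scatter), so this position tolerates 4-phenyl-1H-imidazol-2-yl, a group with more heavy atoms, without a change that can be told from scatter. The earlier pair showed only a chloro change on the shared core, whereas this step alters the group on the sulfur itself. No supporting measurement is available to explain this result. From the compounds shown here alone, it remains open whether an amine or a carboxylic acid on the phenyl ring would be tolerated equally. A plain 1H-imidazol-2-yl on the sulfur also remains untested within the compounds shown.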